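A few compounds are considered here, and "the series" means these few. Any claim that something is new, unique, unknown or untested is made for them only; others in the source may bear on it.

Compound 1, with the structure `O=C1C(c2ccccc2)CC(c2ccccc2)C(=O)N1Cc1ccccc1`, opens the series; in a functional assay on the whole organism (strain Swiss albino) for inhibition, with Mus musculus as the target, in the maximal electroshock model, with a stated time of 2 h, at a dose of 25 mg/kg by the intraperitoneal route (on this read-out lower numbers stand for less inhibition and higher numbers for more inhibition at the one dose given (going by the name of the read-out)), compound 1 gives 64.5%. Compound 2, `NN1C(=O)C(c2ccccc2)CC(c2ccccc2)C1=O`, keeps the same core but carries the change (amino in place of benzyl on an amide-type nitrogen in a ring), and in this assay compound 2 gives 76%. The step of a number 11.5 percentage points higher from compound 1 to compound 2 (beyond the scatter) is the one measured effect of this change in the set.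

Compound 3, `O=C1C(c2ccccc2Cl)CC(c2ccccc2Cl)C(=O)N1Cc1ccccc1`, stands on a different core; the difference between the two cores is not broken down here. In this assay compound 3 gives 58.2%, and its values beside those of compound 1 and compound 2 show that the gap to compound 1 lies within the scatter while the gap to compound 2 lies beyond it.

Compound 4, `NN1C(=O)C(c2ccccc2Cl)CC(c2ccccc2Cl)C1=O`, has not yet been measured. It arises from compound 3 by amino in place of benzyl on an amide-type nitrogen in a ring. Among the compounds with values here, this is the same kind of change as the one from compound 1 to compound 2, not the same: in the earlier case the two ring atoms each bear a phenyl group, here each bears a 2-chlorophenyl group.

Within the data shown here, since only one measured step of this kind is available, the expectation for compound 4 rests on compound 2 and the step of a number 11.5 percentage points higher from compound 1 to compound 2 (beyond the scatter); a step of about the same size is expected, a number 10.8 percentage points higher from compound 3 to compound 4 (beyond the scatter). Compound 4 is therefore estimated to give 69% in this assay. For compound 4 the expected range runs from 58% to 80%.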

Compound 4, a percentage reported as inhibition, in the whole organism at one dose (the size of the read-out at that dose, not a potency): 73.3%
Beside the measured number, compound 4's estimate is 4.3 percentage points below it; the range from low to high includes it.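

In this assay, amino in place of benzyl on the amide-type nitrogen in a ring again moves the read-out upward on the core of compound 3: a number 15.1 percentage points higher from compound 3 to compound 4 (beyond the scatter). Set beside the earlier step, the change carries over from the core whose two ring atoms each bear a phenyl group to the core whose two ring atoms each bear a 2-chlorophenyl group, with no difference in size that can be told apart: the same change on two cores in this assay, a number 11.5 percentage points higher (beyond the scatter) from compound 1 to compound 2 and a number 15.1 percentage points higher (beyond the scatter) from compound 3 to compound 4, 3.6 percentage points apart, within the scatter of two such steps. This shows a consistent step on these two cores, at a single dose and a single stated time, but two pairs do not establish that it would hold on any other core, and they do not show why the change raises the number or how potency would shift.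

The compounds shown leave open how a methyl group, a hydroxyl group or a longer chain on that nitrogen would compare with amino and benzyl. They also leave open how the same change would behave on ring atoms that each bear a fluorophenyl or a methoxyphenyl group instead of phenyl or 2-chlorophenyl.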